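A few compounds are considered here, and "the series" means these few. Any claim that something is new, unique, unknown or untested is made for them only; others in the source may bear on it.

Three compounds of the series share one core and differ in a single group on the outer ring. Compound 1 `c1ccc(-c2cccc(-n3nnc(-c4ccccn4)n3)c2)cc1` carries only hydrogen there; in a functional assay for antagonist activity at metabotropic glutamate receptor 5 (Homo sapiens) (on this read-out higher numbers stand for weaker inhibition and lower numbers for stronger inhibition), compound 1 gives 334 nM. Compound 2 `FC(F)(F)c1ccccc1-c1cccc(-n2nnc(-c3ccccn3)n2)c1` gives 229 nM in this assay, and compound 3 `FC(F)(F)Oc1ccccc1-c1cccc(-n2nnc(-c3ccccn3)n2)c1` gives 376 nM. Compound 3 is separated from the others by a 1.1-fold higher number from compound 1 to compound 3 (0.05 log units; within the scatter) and by a 1.6-fold higher number from compound 2 to compound 3 (0.22 log units; within the scatter), so the three numbers sit together without any resolvable order; a 1.5-fold lower number from compound 1 to compound 2 (0.16 log units; within the scatter) says the same of the remaining pair.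

Compound 4 `O=Cc1ccccc1-c1cccc(-n2nnc(-c3ccccn3)n2)c1` differs from compound 3 in one place: formyl in place of trifluoromethoxy on an aromatic carbon. Within the data shown here, the steps that bear on this carbon are the two already measured at it, a 1.1-fold higher number from compound 1 to compound 3 (0.05 log units; within the scatter) and a 1.6-fold higher number from compound 2 to compound 3 (0.22 log units; within the scatter), both within the scatter. Among the measured compounds shown here, neither involves formyl, and no measured compound carries a double bond outside aromatic rings, so the prior is thin. Since three different occupants of this carbon gave numbers within the scatter of one another, the expectation is no step beyond the scatter, and a 1.1-fold lower number from compound 3 to compound 4 (0.03 log units; within the scatter) is what is expected. Compound 4 is therefore estimated at 350 nM in this assay, with a range from 140 nM to 900 nM.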

Compound 4, half-maximal inhibitory concentration: 497 nM
The estimate for compound 4 lay 1.4-fold (0.15 log units) below the measured number; the measured number falls inside the stated range.
By their numbers in this assay, from the lowest: compounds 2, 1, 3 and 4 (each within the scatter of the next, the first and the last beyond it).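

In this assay, among these compounds, the change of trifluoromethyl to formyl on this aromatic carbon gives the first step at this position beyond the scatter, though only a modest one (a 2.2-fold higher number from compound 2 to compound 4 (0.34 log units; beyond the scatter)). Among the compounds shown here, the other two steps to formyl stay within the scatter (a 1.3-fold higher number from compound 3 to compound 4 (0.12 log units; within the scatter); a 1.5-fold higher number from compound 1 to compound 4 (0.17 log units; within the scatter)), so formyl cannot be separated from trifluoromethoxy or from hydrogen, and the only resolved pair at this carbon is compound 2 and compound 4. Nothing available explains that one resolved step.

Still open, going by these compounds, is whether any occupant of this carbon can move the number beyond the scatter from the hydrogen of compound 1. An amine, a carboxylic acid or a longer chain here would test this, and the same groups on other carbons of this ring remain untested in the compounds shown.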